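Swapping an aryl for a styryl on a shared core

This account rests on a few compounds, and the source may have more. Where it says the series, first, only, none or still open, it means among the compounds named here.

Of the compounds shown here, three built on one shared core have been tested in an ADME assay on HepG2 cells (Homo sapiens) for cytotoxicity, read by MTT assay, with a stated time of 72 h; a lower number here means that less compound is tolerated, a higher number that more compound is tolerated. Compound 1 `Fc1ccc(/C=N/c2sc3c(c2-c2nc4ccccc4s2)CCCC3)cc1` gives 324 ug/mL. Compound 2 `Clc1ccc(/C=N/c2sc3c(c2-c2nc4ccccc4s2)CCCC3)c(Cl)c1` gives 384 ug/mL, and compound 3 `FC(F)(F)c1ccc(/C=N/c2sc3c(c2-c2nc4ccccc4s2)CCCC3)cc1` gives 361 ug/mL. The steps between them are all small: a 1.2-fold higher number from compound 1 to compound 2 (0.07 log units; within the scatter), a 1.1-fold higher number from compound 1 to compound 3 (0.05 log units; within the scatter) and a 1.1-fold lower number from compound 2 to compound 3 (0.03 log units; within the scatter). Compound 3 thus stands among three numbers that all lie within the scatter of one another, so none of them can be set apart from the rest.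

Compound 4 `C(=C/c1ccccc1)\C=N\c1sc2c(c1-c1nc3ccccc3s1)CCCC2` differs from compound 3 by a single change: 2-phenylethenyl in place of 4-(trifluoromethyl)phenyl on a carbon with a double bond to nitrogen. The three measured steps all bear on this position, since each exchanges one substituted phenyl for another on the same carbon, and none moved the number beyond the scatter. Going by the values given here, no measured step, however, brings in a group with a double bond outside an aromatic ring, so the change to compound 4 goes further than any of them; this widens the uncertainty without pointing in a direction. The expected step is a 1.0-fold lower number from compound 3 to compound 4 (0.01 log units; within the scatter), that is no change beyond the scatter. Compound 4 is therefore estimated at 350 ug/mL, with a range from 200 ug/mL to 600 ug/mL.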

Compound 4, half-maximal cytotoxic concentration: 467 ug/mL
Estimate against measurement, compound 4: 1.3-fold (0.13 log units) below; measured number inside the range.
By their numbers in this assay, from the lowest: compounds 1, 3, 2 and 4 (each within the scatter of the next).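

Going by these compounds alone, compound 4 brings the first group at this position with a double bond outside an aromatic ring, and in this assay the picture holds, with a 1.3-fold higher number from compound 3 to compound 4 (0.11 log units; within the scatter) and with a 1.2-fold higher number from compound 2 to compound 4 (0.08 log units; within the scatter) and also with a 1.4-fold higher number from compound 1 to compound 4 (0.16 log units; within the scatter) as the three new steps. The position on a carbon with a double bond to nitrogen therefore accepts 2-phenylethenyl as well as the substituted phenyl groups without any step leaving the scatter, so the earlier finding now reaches beyond exchanges of one substituted phenyl for another, and none of the four compounds goes against it. No measurement is at hand that would explain why the numbers stay so close together.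

As far as these compounds go, every group placed here so far contains a six-membered aromatic ring of carbon only, so it remains open how the number would respond to an amine, a carboxylic acid or a plain alkyl chain on this carbon. The shared core is also identical in all four compounds, which leaves open whether this same tolerance would hold if another part of the core were changed.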